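The source may hold more compounds than are shown below. What is called first, only, known or untested is meant among the compounds shown, and "the series" means these compounds.

Compound 1, `CC(C)(C)OC(=O)N1CCC(O[C@H]2CC[C@@H](Oc3ccc(S(C)(=O)=O)cc3)CC2)CC1`, and its mirror image compound 2, `CC(C)(C)OC(=O)N1CCC(O[C@H]2CC[C@H](Oc3ccc(S(C)(=O)=O)cc3)CC2)CC1`, were both tested in a functional assay on isolated protein for agonist activity at Glucose-dependent insulinotropic receptor (Homo sapiens), read by HTRF and cAMP accumulation; on this read-out lower numbers stand for smaller maximal responses and higher numbers for larger maximal responses. Compound 1 gives 120% and compound 2 gives 115%, a step of a number 5 percentage points lower from compound 1 to compound 2 (within the scatter), so compound 2 stands at the lower of the two numbers while still within the scatter. Compound 3, `CC(C)(C)OC(=O)N1CCC(O[C@H]2CC[C@H](Oc3ccc(S(C)(=O)=O)cc3F)CC2)CC1`, differs from compound 2 by fluoro in place of hydrogen on an aromatic carbon. Going by the values given here, the only measured step concerns configuration alone and says nothing about a fluoro group, so a step of about a number 3 percentage points lower from compound 2 to compound 3 (within the scatter) is expected, nothing beyond the scatter. Compound 3 is estimated to reach 112%, between 85% and 135%.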

Compound 3, largest response reached (Emax), in percent of the reference or control that the assay uses: 113%
Compound 3: middle estimate off by 1 percentage points, on the low side, and the stated range covers the measured number.
By their numbers in this assay, from the lowest: compounds 3, 2 and 1 (each within the scatter of the next).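

Replacing hydrogen with fluoro on this aromatic carbon, ortho to a large group and meta to a methylsulfonyl group, gives in this assay a step of a number 2 percentage points lower from compound 2 to compound 3 (within the scatter), so this one change does not separate the two compounds. The earlier pair spoke only to configuration; this step shows that the ring itself can carry a fluoro with the maximal response still within the scatter. Nothing shown here bears on the reason for this result. Open, from the compounds shown here alone, is whether chloro, methoxy or an amine at this place would behave alike, and whether fluoro would do the same on compound 1.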